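Dropping One Fluorine: An Expectation for Compound 4

The source may report more compounds than this note shows. Statements on the series, on what has been measured and on what is new or still open speak of the compounds shown alone.

Compound 1 `CCCCCCCCn1cc(/C=C/C(=O)c2ccc(NC(=O)CN3CCN(c4ccccc4F)CC3)cc2)nn1`: 60300 nM
Compound 2 `CCCCCCCCCCn1cc(/C=C/C(=O)c2ccc(NC(=O)CN3CCN(c4ccccc4)CC3)cc2)nn1`: 39500 nM
Compound 3 `O=C(CN1CCN(c2ccccc2F)CC1)Nc1ccc(C(=O)/C=C/c2cn(Cc3ccc(Br)cc3)nn2)cc1`: 12800 nM

In a functional assay on SK-N-SH cells (Homo sapiens) for inhibition, read by MTT assay (on this read-out higher numbers stand for weaker inhibition and lower numbers for stronger inhibition), compound 3 gives the lowest of the three numbers, and both compound 1 and compound 2 give higher ones. Compound 4 `O=C(CN1CCN(c2ccccc2)CC1)Nc1ccc(C(=O)/C=C/c2cn(Cc3ccc(Br)cc3)nn2)cc1` differs from compound 3 by hydrogen in place of fluoro on an aromatic carbon. Among the measured compounds shown here, no measured pair isolates this change. For the measured compounds named here, the only single-place step, a 4.7-fold lower number from compound 1 to compound 3 (0.67 log units; beyond the scatter), concerns another part of the molecule. Compound 1, bearing the fluoro, and compound 2, lacking it, also differ in their chain, so their values can only be set side by side: compound 1 gives 60300 nM and compound 2 gives 39500 nM. The step from compound 3 to compound 4 is therefore expected to be small, a 1.2-fold lower number from compound 3 to compound 4 (0.07 log units; within the scatter), in either direction. Compound 4 is expected at 11000 nM, within 4000 nM to 30000 nM.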

Compound 4, half-maximal inhibitory concentration: 72400 nM
The estimate for compound 4 lay 6.6-fold (0.82 log units) below the measured number; measured number outside the range, above it.
By their numbers in this assay, from the lowest: compound 3; then compounds 2, 1 and 4 (each within the scatter of the next).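

In this assay the change from 2-fluorophenyl to phenyl is not neutral: a 5.7-fold higher number from compound 3 to compound 4 (0.75 log units; beyond the scatter) shows that this single fluoro matters when 4-bromophenyl is present. Without the fluoro, 4-bromophenyl in place of nonyl gives only a 1.8-fold higher number from compound 2 to compound 4 (0.26 log units; within the scatter) and stays within the scatter, whereas with the fluoro, 4-bromophenyl in place of heptyl gave a 4.7-fold lower number from compound 1 to compound 3 (0.67 log units; beyond the scatter) and went beyond it, though those two chains differ. Nothing available explains this step.

On these data alone, whether chloro or methoxy on the same aromatic carbon would match the fluoro remains open.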